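Alkoxy variation on the shared core: lipophilicity notes

The source may report more compounds than this note shows. Statements on the series, on what has been measured and on what is new or still open speak of the compounds shown alone.

Going by the values given here, compound 1 `COc1ccc(-c2[nH]c3ccccc3c2C2=C(Br)C(=O)NC2=O)cc1` is the most polar of the three measured members: in a physicochemical assay for lipophilicity (a higher number here means a more lipophilic compound, a lower number a more polar compound), compound 1 gives 2.42, the lowest of the three numbers. Compound 2 `CCCCCOc1ccc(-c2[nH]c3ccccc3c2C2=C(Br)C(=O)NC2=O)cc1` gives 4.2 and compound 3 `O=C1NC(=O)C(c2c(-c3ccc(OCc4cccc5ccccc45)cc3)[nH]c3ccccc23)=C1Br` gives 3.76. Both measured steps from compound 1 enlarge the group on a saturated chain carbon bound to an oxygen on an aromatic ring: a number 1.78 log units higher from compound 1 to compound 2 (beyond the scatter), and a number 1.34 log units higher from compound 1 to compound 3 (beyond the scatter). Between the two larger compounds, a number 0.44 log units lower from compound 2 to compound 3 (beyond the scatter).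

Compound 4 `CCOc1ccc2[nH]c(-c3ccc(OC)cc3)c(C3=C(Br)C(=O)NC3=O)c2c1` is not yet measured. Relative to compound 1 the change is ethoxy in place of hydrogen on an aromatic carbon. Among the compounds with values here, no measured step touches this place on the core, and both measured steps add larger groups than the ethoxy entering here, so they frame the expectation only from above. A rise in this assay is expected, clearly smaller than either measured step from compound 1 and close to the edge of the scatter. The expected step is a number 0.48 log units higher from compound 1 to compound 4 (beyond the scatter). Compound 4 is estimated at 2.9, with a range from 2.5 to 3.4.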

Compound 4, partition coefficient: 2.77
Compound 4: middle estimate off by 0.13 log units, on the high side, within the range that was stated.
By their numbers in this assay, from the lowest: compound 1; then compound 4; then compound 3; then compound 2.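

In this assay, the ethoxy group gives the only step shown on an aromatic carbon of the six-membered aromatic ring of carbon only, part of a fused or bridged system of two rings: a number 0.35 log units higher from compound 1 to compound 4 (beyond the scatter). The number therefore moves beyond the scatter at this place too, and not only on the saturated chain carbon bound to an oxygen, with an entering group of just 3 heavy atoms, no ring and no hydrogen-bond donor. No measurement shown here accounts for the size of this step, and this single pair at the new place gives no trend along a set of groups.

Ethoxy is the only group shown at this place, so it remains open how the number would respond to an amine, a carboxylic acid or a longer chain such as pentyloxy on the same aromatic carbon. On these data alone, compound 4 also differs from compound 2 and compound 3 in more than one place, so it remains open whether a change at this place and a larger group on the chain carbon bound to an oxygen would add up in one compound.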